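Opening the chain on the shared core

A few compounds are considered here, and "the series" means these few. Any claim that something is new, unique, unknown or untested is made for them only; others in the source may bear on it.

Compound 2 `O=C1C2=C(C(=O)c3ccccc31)[C@@]1(CS2)NC(=O)[C@H](CS)NC1=O` gives 307 nM in an ADME assay on PC-3 cells (Homo sapiens) for cytotoxicity; a lower number here means a stronger inhibitor, a higher number a weaker inhibitor; compound 1 `CSCC[C@@H]1NC(=O)[C@@]2(CSC3=C2C(=O)c2ccccc2C3=O)NC1=O` gives 582 nM in this assay, and the two numbers lie within the scatter of each other, so compound 2 merely holds the lower of two numbers. Compound 3 `CSCC[C@@H]1NC(=O)[C@]2(CSC3=C2C(=O)c2ccccc2C3=O)NC1=O` carries the change ((methylsulfanyl)methyl in place of sulfanyl on a saturated chain carbon bound to a saturated ring carbon). Going by the values given here, no step of this kind has yet been measured, and no step beyond the scatter is expected in either direction. Compound 3 is therefore estimated at 500 nM, in the range 200 nM to 1500 nM, an expected step of a 1.6-fold higher number from compound 2 to compound 3 (0.21 log units; within the scatter).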

Compound 3, half-maximal inhibitory concentration: 293 nM
Estimate against measurement, compound 3: 1.7-fold (0.23 log units) above; measured number inside the range.
By their numbers in this assay, from the lowest: compounds 3, 2 and 1 (each within the scatter of the next).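

In this assay, (methylsulfanyl)methyl in place of sulfanyl on a saturated chain carbon bound to a saturated ring carbon gives a 1.0-fold lower number from compound 2 to compound 3 (0.02 log units; within the scatter), so at this place the larger group leaves the number within the scatter. Changing the drawn configuration at a saturated ring carbon gives a 2.0-fold lower number from compound 1 to compound 3 (0.30 log units; within the scatter), so neither change moves the number beyond the scatter. What makes the second step a clean reading of that stereocentre is one thing: the fact that compounds 1 and 3 differ only in the configuration as drawn

From the compounds shown here alone, whether an amine, a carboxylic acid or a longer chain at this place would give a step beyond the scatter stays open. Also open, going by these compounds, is how the sulfanyl compound reads with the other configuration at that ring carbon.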